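Chloro to bromo on the pendant phenyl: an estimate

The source may hold more compounds than are shown below. What is called first, only, known or untested is meant among the compounds shown, and "the series" means these compounds.

Measured compounds:
- compound 1, `Cn1ccc2c(Oc3ccc(NC(=O)c4cc5cccnc5n(-c5ccccc5)c4=O)cc3F)ccnc21`, 550 nM in a functional assay on NCI-H460 cells (Homo sapiens) for antiproliferative activity, read by MTT assay, with a stated time of 72 h; a lower number here means a stronger inhibitor, a higher number a weaker inhibitor
- compound 2, `Cn1ccc2c(Oc3ccc(NC(=O)c4cc5cccnc5n(-c5ccc(F)cc5)c4=O)cc3F)ccnc21`, 250 nM
- compound 3, `Cn1ccc2c(Oc3ccc(NC(=O)c4cc5cccnc5n(-c5ccc(Cl)cc5)c4=O)cc3F)ccnc21`, "not determined" (no result reported)

All three share one core and differ only in the group on the phenyl that hangs from the core. Compound 1 carries an unsubstituted phenyl, and the change to a fluoro-bearing phenyl gave a 2.2-fold lower number from compound 1 to compound 2 (0.34 log units; beyond the scatter). Compound 3 carries a chloro on that same phenyl, but no number is available for it in this assay, so its standing among the measured compounds cannot be read from the data shown.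

Compound 4, `Cn1ccc2c(Oc3ccc(NC(=O)c4cc5cccnc5n(-c5ccc(Br)cc5)c4=O)cc3F)ccnc21`, is the next step: bromo in place of chloro on an aromatic carbon. For the measured compounds named here, no measured step bears directly on this change; the only measured step, from hydrogen to fluoro, touches the same position but not the same exchange. With nothing to anchor a direction, the expectation is a step of no size beyond the scatter between compound 3 and compound 4, and the value of compound 2 serves as the nearest measured reference for a halogen at that position. The estimate for compound 4 in this assay is 250 nM, within 80 nM to 800 nM.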

Compound 4, half-maximal inhibitory concentration: 420 nM
Beside the measured number, compound 4's estimate is 1.7-fold (0.23 log units) below it; the range from low to high includes it.
By their numbers in this assay, from the lowest: compounds 2, 4 and 1 (each within the scatter of the next, the first and the last beyond it).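

On this phenyl, bromo gives a 1.7-fold higher number from compound 2 to compound 4 (0.23 log units; within the scatter) and a 1.3-fold lower number from compound 1 to compound 4 (0.12 log units; within the scatter) in this assay, so compound 4 cannot be told apart from either compound with these data, even though compound 1 and compound 2 are separated from each other. The gain seen with fluoro, a 2.2-fold lower number from compound 1 to compound 2 (0.34 log units; beyond the scatter), is therefore not shown to carry over clearly to bromo, so a result for one halogen at this place is a poor guide to another, and the direct step from chloro to bromo cannot be read, as compound 3 has no number. Nothing in the data on hand offers an explanation for these results.

Going by these compounds, what chloro itself does at this place remains open, and so does whether any halogen there truly differs from the plain phenyl of compound 1 once repeat measurements narrow the scatter. Also open is how groups of a different kind, such as a methoxy, an amine or a carboxylic acid, would fare on this same phenyl, since the compounds shown carry only hydrogen or a halogen there.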